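This account rests on a few compounds, and the source may have more. Where it says the series, first, only, none or still open, it means among the compounds named here.

Compound 2 `NS(=O)(=O)c1ccc(N2N=C(c3ccc(Oc4ccccc4)cc3)CC2c2ccccc2F)cc1` carries a 2-fluorophenyl group on a saturated ring carbon of the shared core. In an ADME assay on MT4 cells (Homo sapiens) for cytotoxicity, read by MTT assay, with a stated time of 96 h (on this read-out lower numbers stand for higher toxicity in this test and higher numbers for lower toxicity in this test), compound 2 gives 36000 nM. Its two measured neighbours sit within the scatter of it on either side: compound 1 `Cc1cccc(C2CC(c3ccc(Oc4ccccc4)cc3)=NN2c2ccc(S(N)(=O)=O)cc2)c1`, which bears a 3-methylphenyl group instead, gives 35000 nM in this assay, and compound 3 `NS(=O)(=O)c1ccc(N2N=C(c3ccccc3)CC2c2ccccc2F)cc1`, which lacks the phenoxy group, gives 42000 nM. The step of a 1.0-fold higher number from compound 1 to compound 2 (0.01 log units; within the scatter) and the step of a 1.2-fold higher number from compound 2 to compound 3 (0.07 log units; within the scatter) are both within the scatter, so no change in this series has yet moved the read-out. Compound 4 `NS(=O)(=O)c1ccc(N2N=C(c3ccc(Oc4ccccc4)cc3)CC2c2ccccc2Cl)cc1` differs from compound 2 by chloro in place of fluoro on an aromatic carbon, placed on an aromatic carbon of a six-membered aromatic ring of carbon only, ortho to a large group. The step from compound 1 to compound 2 is the one that bears most on it, since it also exchanges the group on that saturated ring carbon, and it was flat. Compound 4 is therefore expected to show no change at the digits printed from compound 2 to compound 4 (within the scatter), no step beyond the scatter. The estimated value of compound 4 is 36000 nM, with a range from 18000 nM to 72000 nM.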

Compound 4, half-maximal cytotoxic concentration: 40000 nM
The estimate for compound 4 lay 1.1-fold (0.05 log units) below the measured number, within the range that was stated.
By their numbers in this assay, from the lowest: compounds 1, 2, 4 and 3 (each within the scatter of the next).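

In this assay, the exchange at the aromatic carbon ortho to a large group is flat: chloro in place of fluoro gives a step (a 1.1-fold higher number from compound 2 to compound 4 (0.05 log units; within the scatter)). Earlier compounds changed the whole group on the saturated ring carbon or removed the phenoxy group, whereas this pair isolates a single halogen exchange on that aromatic carbon. The step with 2-chlorophenyl in place of 3-methylphenyl (a 1.1-fold higher number from compound 1 to compound 4 (0.06 log units; within the scatter)) adds a further exchange of that group without moving the read-out beyond the scatter, and nothing available here accounts for this flatness.

The compounds shown leave open whether an amine or a carboxylic acid on that aromatic carbon would shift the read-out. Going by these compounds alone, with every step so far within the scatter, they also do not show which part of the shared core, if any, governs this read-out.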